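A few compounds are considered here, and "the series" means these few. Any claim that something is new, unique, unknown or untested is made for them only; others in the source may bear on it.

Working notes on the bis(trifluoromethyl)benzenesulfonamide series.

Among the compounds with values here, compound 3 `CN(CCCNS(=O)(=O)c1cc(C(F)(F)F)cc(C(F)(F)F)c1)Cc1ccccc1` gives in a functional assay on ASPC1 cells (Homo sapiens) for inhibition, read by MTT assay, with a stated time of 72 h (on this read-out lower numbers stand for stronger inhibition of growth and higher numbers for weaker inhibition of growth), a value of 51000 nM, the highest number of the three compounds measured so far. Compound 1 `O=S(=O)(NCCCNCc1ccccc1Cl)c1cc(C(F)(F)F)cc(C(F)(F)F)c1` gives 13000 nM in this assay, and compound 2 `CC(C)(C)c1ccc(CNCCCNS(=O)(=O)c2cc(C(F)(F)F)cc(C(F)(F)F)c2)cc1` gives 2700 nM in this assay. Of the two single-point steps, a 3.9-fold higher number from compound 1 to compound 3 (0.59 log units; beyond the scatter), whereas a 4.8-fold lower number from compound 1 to compound 2 (0.68 log units; beyond the scatter).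

Compound 4 `O=S(=O)(NCCCNCc1cccc(Cl)c1)c1cc(C(F)(F)F)cc(C(F)(F)F)c1` has not yet been measured. It differs from compound 3 by (3-chlorobenzyl)amino in place of benzyl(methyl)amino on a saturated chain carbon, three bonds along the chain from a sulfonamide nitrogen. Within the data shown here, the step bearing most directly on this is the one from compound 1 to compound 3, run in reverse: the methyl on the amine nitrogen is removed and a chlorine returns to the benzyl ring, though now at the 3-position rather than the 2-position of compound 1. The step from compound 1 to compound 2 shows that the substitution of the benzyl ring itself moves this assay by a modest amount, so the difference between a 2-chloro and a 3-chloro ring cannot be read from the data and is left open. Compound 4 is therefore expected to land near compound 1, with a 5.1-fold lower number from compound 3 to compound 4 (0.71 log units; beyond the scatter) as the estimated step. The estimate for compound 4 in this assay is 10000 nM, with a range from 3000 nM to 35000 nM.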

Compound 4, concentration for 50% growth inhibition: 5900 nM
The estimate for compound 4 lay 1.7-fold (0.23 log units) above the measured number; the measured number falls inside the stated range.
By their numbers in this assay, from the lowest: compound 2; then compound 4; then compound 1; then compound 3.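

The change from benzyl(methyl)amino to (3-chlorobenzyl)amino carries (an 8.6-fold lower number from compound 3 to compound 4 (0.94 log units; beyond the scatter)) in this assay, but this single step joins two changes, the loss of the methyl on the amine nitrogen and the gain of a chlorine, and the data cannot divide it between them. New here is that the place of the chlorine on the ring counts: 3-chlorophenyl in place of 2-chlorophenyl gives (a 2.2-fold lower number from compound 1 to compound 4 (0.34 log units; beyond the scatter)), a difference the earlier compounds could not show. Even so, 3-chlorophenyl does not reach 4-(tert-butyl)phenyl (a 2.2-fold higher number from compound 2 to compound 4 (0.34 log units; beyond the scatter)), so among the three compounds without the methyl the order from lowest number runs 4-(tert-butyl)phenyl, 3-chlorophenyl, 2-chlorophenyl, and this order holds for these compounds alone.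

Nothing at hand gives a cause for any of these steps. Still open, going by these compounds, is how much of the gap to compound 3 belongs to the methyl and how much to the chlorine, which the plain benzylamino group and the (3-chlorobenzyl)(methyl)amino group would separate, while a 4-chlorophenyl group would complete the chlorine comparison.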